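Shortening the Alkyne Chain of a Phthalimide-Linked Uracil

The source may hold more compounds than are shown below. What is called first, only, known or untested is meant among the compounds shown, and "the series" means these compounds.

Three compounds share a core in which a uracil ring carries a triple-bonded substituent and, through a short unsaturated linker, a phthalimide group. In a functional assay on MOLT-4 cells (Homo sapiens) for antiproliferative activity, read by MTT assay, with a stated time of 3 days (on this read-out lower numbers stand for stronger inhibition and higher numbers for weaker inhibition), compound 1 `CCCCCCC#Cc1cn(C/C=C/CN2C(=O)c3ccccc3C2=O)c(=O)[nH]c1=O` gives 35000 nM, compound 2 `CCCCc1ccc(C#Cc2cn(C/C=C\CN3C(=O)c4ccccc4C3=O)c(=O)[nH]c2=O)cc1` gives 31000 nM and compound 3 `CCCCCc1ccc(C#Cc2cn(C/C=C/CN3C(=O)c4ccccc4C3=O)c(=O)[nH]c2=O)cc1` gives 17000 nM. For the measured compounds named here, compound 1 thus shows the highest number of the three; compound 2 sits within the scatter of it, while compound 3 lies beyond the scatter, the only measured step being a 2.1-fold lower number from compound 1 to compound 3 (0.31 log units; beyond the scatter).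

Compound 4 `CCCCCC#Cc1cn(C/C=C/CN2C(=O)c3ccccc3C2=O)c(=O)[nH]c1=O` has not yet been measured. The change from compound 1 to compound 4 is hydrogen in place of methyl on a saturated chain carbon, five bonds along the chain from a triple-bonded carbon. Going by the values given here, no measured step touches this kind of change: the one step recorded swaps the whole hexyl for 4-pentylphenyl, and compound 2 differs from compound 1 in more than one place, so only their two values can be compared. Removing a single methyl from the end of a saturated chain is a smaller alteration than either of those, and there is no sign in the data that this part of the molecule is sensitive.

Compound 4 is therefore expected to give about 40000 nM in this assay, with a range of 20000 nM to 80000 nM. The step that this estimate means, a 1.1-fold higher number from compound 1 to compound 4 (0.06 log units; within the scatter), is expected to stay within the scatter.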

Compound 4, half-maximal inhibitory concentration: > 500000 nM
Compound 4: a limit, no number (the forecaster's own chance of this, stated with the estimate: 15%); at least 12-fold (1.09 log units) between middle value and limit.
By their numbers in this assay, from the lowest: compounds 3, 2 and 1 (each within the scatter of the next, the first and the last beyond it). At a limit, above all of these: compound 4.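

The reading for compound 4 in this assay is a limit of the assay and not a number: the limit of > 500000 nM in this assay, at which 1 of the 4 values shown sits.

Even so, the change at this position can be sized: hydrogen in place of methyl, on a saturated chain carbon, five bonds along the chain from a triple-bonded carbon, gives an at least 14-fold higher number from compound 1 to compound 4 (1.15 log units; beyond the scatter), so the end of this chain, which no earlier step had touched, proves sensitive to the loss of a single carbon. The second new step, with pentyl in place of 4-pentylphenyl on a triple-bonded carbon, gives an at least 29-fold higher number from compound 3 to compound 4 (1.46 log units; beyond the scatter), so in this pair a pentyl group alone does not match the result obtained with the 4-pentylphenyl group.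

With only hexyl and pentyl as saturated chains here, these compounds do not show whether a longer chain such as heptyl or octyl would keep, improve or lose the activity of the hexyl compound, or whether the sharp loss continues with a shorter chain such as butyl. They also leave open whether a chain ending in a hydroxyl group or an amine would behave like hexyl or like pentyl.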